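This account rests on a few compounds, and the source may have more. Where it says the series, first, only, none or still open, it means among the compounds named here.

Measured compounds:
- Compound 1, `Oc1cccc(-c2cc(-c3ccncc3)nc(-c3cccc(Cl)c3)c2)c1` – "not determined" (no result reported) in a functional assay on HCT-15 cells (Homo sapiens) for cytotoxicity, read by CCK-8 assay and cell counting, with a stated time of 2 days; a higher number here means a weaker inhibitor, a lower number a stronger inhibitor
- Compound 2, `Oc1cccc(-c2cc(-c3ccc(Cl)cc3)nc(-c3cccs3)c2)c1` – 9280 nM
- Compound 3, `Oc1cccc(-c2cc(-c3ccc(Cl)cc3)nc(-c3ccccn3)c2)c1` – 13500 nM

All three share the same core, a ring carrying a 3-hydroxyphenyl group, a chlorophenyl group and a third aromatic group. For compound 1 no number was reported. Compound 2 and compound 3 each have a 4-chlorophenyl group and differ only in the third group: a 1.5-fold higher number from compound 2 to compound 3 (0.16 log units; within the scatter). Compound 3 and compound 2 therefore give numbers that lie within the scatter of each other, so no order between them can be claimed.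

Compound 4, `Oc1cccc(-c2cc(-c3ccncc3)nc(-c3ccc(Cl)cc3)c2)c1`, is made from compound 3 by a change that keeps every atom but joins them differently: pyridin-4-yl in place of pyridin-2-yl on an aromatic carbon. Going by the values given here, no measured step tests this exact swap; the only step in hand, from a thiophen-2-yl to a pyridin-2-yl group, stayed within the scatter, and the one compound with a pyridin-4-yl group, compound 1, gave no number. With nothing pointing either way, no shift beyond the scatter is expected in this assay, which is to say a step of a 1.0-fold lower number from compound 3 to compound 4 (0.02 log units; within the scatter). Compound 4 is estimated at 13000 nM, expected to fall between 5000 nM and 35000 nM.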

Compound 4, half-maximal inhibitory concentration: 2630 nM
Beside the measured number, compound 4's estimate is 4.9-fold (0.69 log units) above it; the whole stated range lies above it.
By their numbers in this assay, from the lowest: compound 4; then compounds 2 and 3 (each within the scatter of the next).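

In this assay, the shift of the point of attachment gives a 5.1-fold lower number from compound 3 to compound 4 (0.71 log units; beyond the scatter), even though no atom is added or lost, so this position responds to how the pyridine ring is joined and not only to which atoms it holds. The earlier swap between thiophen-2-yl and pyridin-2-yl showed no such response, whereas pyridin-4-yl also separates from thiophen-2-yl, with a 3.5-fold lower number from compound 2 to compound 4 (0.55 log units; beyond the scatter), so among the groups with a number here, pyridin-4-yl stands apart from the other two. Nothing measured here explains this shift.

As far as these compounds go, whether pyridin-3-yl, or a pyridine ring carrying an amine, would follow pyridin-4-yl or the other two groups remains open. From the compounds shown here alone, with no number for compound 1, it is also open whether pyridin-4-yl keeps its edge alongside a 3-chlorophenyl group.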